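A Methyl Step Repeated on a Related Ester Pair

The source may hold more compounds than are shown below. What is called first, only, known or untested is meant among the compounds shown, and "the series" means these compounds.

Compound 1 `CCCCOC(=O)/C=C(C)/C=C/CC(C)CCCC(C)(C)OC` gives 6.62 in a physicochemical assay for lipophilicity; on this read-out higher numbers stand for higher lipophilicity and lower numbers for lower lipophilicity. Compound 2 `COC(C)(C)CCCC(C)C/C=C/C(C)=C/C(=O)OCCC(C)C` gives 7.03 in this assay, and the step of a number 0.41 log units higher from compound 1 to compound 2 (beyond the scatter) comes from the change (methyl in place of hydrogen on a saturated chain carbon bound to two saturated chain carbons). Compound 3 `CCOC(C)(C)CCCC(C)C/C=C/C(C)=C/C(=O)OC(C)C` gives 6.49 in this assay; the difference between its core and the core of compound 1 is not broken down here. Compound 4 `CC(/C=C/CC(C)CCCC(C)(C)OC(C)C)=C\C(=O)OC(C)C` differs from compound 3 by methyl in place of hydrogen on a saturated chain carbon bound to an oxygen on a saturated carbon and a saturated chain carbon. The place is not identical: the earlier methyl enters on a saturated chain carbon bound to two saturated chain carbons, the new one on a saturated chain carbon bound to an oxygen on a saturated carbon and a saturated chain carbon, so this is the same kind of change rather than the same change. A step of about the earlier size is expected for compound 4, namely a number 0.41 log units higher from compound 3 to compound 4 (beyond the scatter), resting on a number 0.41 log units higher from compound 1 to compound 2 (beyond the scatter). Compound 4 is therefore estimated at 6.9, expected between 6.6 and 7.2 in this assay.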

Compound 4, partition coefficient: 6.9
Beside the measured number, compound 4's estimate shows no gap at the digits printed; the measured number falls inside the stated range.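

In this series, methyl in place of hydrogen gives a step in this assay (from a number 0.41 log units higher from compound 3 to compound 4 (beyond the scatter)) that matches the earlier one (from a number 0.41 log units higher from compound 1 to compound 2 (beyond the scatter)), so across these two pairs the change carried over from one core to another even though it was made at a different place. Two pairs do not make a rule for the whole series, and they say nothing about what this change would do at other places on these molecules. Nothing available here accounts for the match between the two steps.

The compounds shown leave open whether the same step would appear on a core carrying a carboxylic acid or an amine in place of the ester. They also leave open what a longer chain would do at the place where this methyl enters.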